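A few compounds are considered here, and "the series" means these few. Any claim that something is new, unique, unknown or untested is made for them only; others in the source may bear on it.

Compound 1 `CS(=O)(=O)c1ccc(C(=O)N2CCC(C(=O)N3CCN(c4ccc(F)cc4)CC3)CC2)cc1[N+](=O)[O-]` and compound 2 `CN(Cc1ccccc1)C(=O)C1CCN(C(=O)c2ccc(S(C)(=O)=O)c([N+](=O)[O-])c2)CC1` share a core and differ only in the amine bound to the carbonyl on the saturated ring. In an assay on isolated protein for inhibition of vitamin D3 receptor (Homo sapiens), read by fluorescence polarization (a higher number here means a weaker inhibitor, a lower number a stronger inhibitor), compound 1 gives a value of > 60000 nM, which is a limit of the assay and not a number. In this assay compound 2 likewise gives > 60000 nM, again a limit rather than a number. So compound 2 stands where compound 1 stands, at the limit of > 60000 nM in this assay, at which 2 of the 2 values shown sit, and no step between them can be sized. Compound 3 `CN1CCN(C(=O)C2CCN(C(=O)c3ccc(S(C)(=O)=O)c([N+](=O)[O-])c3)CC2)CC1` follows from compound 2 by 4-methylpiperazin-1-yl in place of benzyl(methyl)amino on a carbonyl carbon. Because both values shown sit at the limit of > 60000 nM in this assay, at which 2 of the 2 values shown sit, no direction for this step can be read from the data, and compound 3 is expected to stay at the limit, with a step that the limit leaves unreadable from compound 2 to compound 3 that should mean no change beyond the scatter. Compound 3 is therefore estimated at 100000 nM, within a range of 30000 nM to 300000 nM.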

Compound 3, half-maximal inhibitory concentration: > 60000 nM
Compound 3: only a limit was reported; the forecaster's own chance of this, stated with the estimate: 85%; the middle value is on the limit's open side.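

In this assay compound 3 gives > 60000 nM, a limit of the assay and not a number, so no step from compound 1 or compound 2 to compound 3 can be read: the limit of > 60000 nM in this assay, at which 3 of the 3 values shown sit.

The compounds shown leave open which amine on the carbonyl, if any, would give a measurable value in this assay.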